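Moving a Methoxy Group on a Benzyl Ether

The source may hold more compounds than are shown below. What is called first, only, known or untested is meant among the compounds shown, and "the series" means these compounds.

Of the compounds shown here, two have been tested in a functional assay on MCF7 cells (Homo sapiens) for antiproliferative activity, read by sulforhodamine B assay, with a stated time of 72 h; on this read-out lower numbers stand for stronger inhibition and higher numbers for weaker inhibition. Compound 1 `Cc1ccc(COc2ccc(-c3cc(CN4CCN(Cc5ccc(C(F)(F)F)cc5)CC4)no3)cc2)cc1` gives 1200 nM in this assay. Compound 2 `COc1ccccc1COc1ccc(-c2cc(CN3CCN(Cc4ccc(C(F)(F)F)cc4)CC3)no2)cc1` carries a 2-methoxyphenyl where compound 1 carries a 4-methylphenyl on a saturated chain carbon bound to an oxygen on an aromatic ring. In this assay compound 2 gives 300 nM. Of the two numbers, that of compound 2 is the lower, and the step of a 4.0-fold lower number from compound 1 to compound 2 (0.60 log units; beyond the scatter) places the gap between them beyond the scatter of this assay.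

Compound 3 `COc1ccc(COc2ccc(-c3cc(CN4CCN(Cc5ccc(C(F)(F)F)cc5)CC4)no3)cc2)cc1` has not yet been measured. It differs from compound 2 in one place: 4-methoxyphenyl in place of 2-methoxyphenyl on a saturated chain carbon bound to an oxygen on an aromatic ring. Within the data shown here, the single measured step, from compound 1 to compound 2, swapped both the group and its place on the ring at once, so no measured step bears cleanly on moving the methoxy group alone; the data hold nothing that separates the two. Compound 3 pairs the 4-methoxyphenyl with the methoxy group seen in compound 2, so its number in this assay is expected to lie between the two measured ones, a step of a 2.3-fold higher number from compound 2 to compound 3 (0.37 log units; beyond the scatter) toward a higher number. Compound 3 is therefore estimated at 700 nM in this assay, within a range from 250 nM to 2000 nM.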

Compound 3, half-maximal inhibitory concentration: 1300 nM
For compound 3 the middle estimate is 1.9-fold (0.27 log units) below the measured one; measured number inside the range.
By their numbers in this assay, from the lowest: compound 2; then compounds 1 and 3 (each within the scatter of the next).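

In this assay the methoxy group changes only its place on the ring, with 4-methoxyphenyl in place of 2-methoxyphenyl, and this gives a 4.3-fold higher number from compound 2 to compound 3 (0.64 log units; beyond the scatter) even though the two compounds have the same atoms, joined differently. This separates what the first step could not, since methoxy in place of methyl on an aromatic carbon gives a 1.1-fold higher number from compound 1 to compound 3 (0.03 log units; within the scatter) and so makes no difference that can be told from the scatter. Among these three compounds, then, the lower number goes with the 2-methoxyphenyl alone: a methoxy group as such does not bring it, as compound 3 shows, and compound 1 and compound 3 cannot be told apart. Nothing available here explains why the place of the methoxy group makes this difference.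

The compounds shown leave open whether the lower number of compound 2 belongs to the methoxy group itself or would also appear with an ethoxy group, a hydroxy group or a chlorine atom in its place. They also leave open whether the same change holds when the benzyl ether oxygen is replaced by an amide or the trifluoromethyl group on the far side of the molecule by a nitrile.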